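Swapping chloro for methoxy on compound 3

The compounds below may be only part of what the source reports. "The series", "measured", "known", "first", "only" and "open" are said of these compounds alone.

Compound 1 `Cc1ccc(-c2nn(-c3ccccc3)cc2C(Nc2nc3cc(C)c(C)cc3s2)c2c(O)ccc3ccccc23)cc1` gives 31200 nM
Compound 2 `Oc1ccc2ccccc2c1C(Nc1nc2ccccc2s1)c1cn(-c2ccccc2)nc1-c1cccc(Cl)c1` gives 20400 nM
Compound 3 `COc1ccc2nc(NC(c3cn(-c4ccccc4)nc3-c3ccc(Cl)cc3)c3c(O)ccc4ccccc34)sc2c1` gives 34500 nM

These three values come from a functional assay on A549 cells (Homo sapiens) for antiproliferative activity, read by MTT assay, with a stated time of 48 h (a lower number here means a stronger inhibitor, a higher number a weaker inhibitor), and lie close together. Compound 3 stands at 34500 nM within the usual scatter of both other compounds, so the three cannot be ranked.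

Compound 4 `COc1ccc(-c2nn(-c3ccccc3)cc2C(Nc2nc3ccc(OC)cc3s2)c2c(O)ccc3ccccc23)cc1` has not been measured yet. Its difference from compound 3 is methoxy in place of chloro on an aromatic carbon in short, methoxy in place of chloro on an aromatic carbon, para to a large group, which turns 4-chlorophenyl into 4-methoxyphenyl.

Among the measured compounds shown here, no measured pair differs in one place only, so this change has no direct precedent here. Compound 1 at 31200 nM and compound 2 at 20400 nM differ from compound 3 in more than one place, yet both stay within the scatter of it. No shift beyond the scatter is therefore expected in this assay and no direction can be favoured. The expected 1.2-fold lower number from compound 3 to compound 4 (0.06 log units; within the scatter) stays within the scatter. Compound 4 is estimated at 30000 nM with 14000 nM to 60000 nM as its expected range.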

Compound 4, half-maximal inhibitory concentration: 28100 nM
The estimate for compound 4 lay 1.1-fold (0.03 log units) above the measured number, and the stated range covers the measured number.
By their numbers in this assay, from the lowest: compounds 2, 4, 1 and 3 (each within the scatter of the next).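

Among the compounds shown here, this is the first pair here that differs in one place only, so the change from 4-chlorophenyl to 4-methoxyphenyl can now be read directly: this assay gives a 1.2-fold lower number from compound 3 to compound 4 (0.09 log units; within the scatter) for it. On this aromatic carbon, para to a large group, methoxy with its 2 heavy atoms and 1 hydrogen-bond acceptor stands in for chloro with its 1 heavy atom and 0 acceptors, and the two compounds stay within the scatter of each other. No measurement shown here accounts for this result.

For the compounds shown here, an amine or a carboxylic acid at this position remains an open case, as only this one swap can be read there. Also open, on these data alone, is whether the same swap would give a similar step on the core of compound 1 or compound 2.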